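Notes on the step from compound 1 to compound 4

The source may report more compounds than this note shows. Statements on the series, on what has been measured and on what is new or still open speak of the compounds shown alone.

Among the measured compounds shown here, in a functional assay on CCRF-CEM cells (Homo sapiens) for antiproliferative activity (a higher number here means that more compound is tolerated, a lower number that less compound is tolerated), compound 1 `Cc1cn(C2OC(CO[Si](C)(C)C(C)(C)C)C3(OS(=O)(=O)C=C3N)C2O[Si](C)(C)C(C)(C)C)c(=O)n(CCCNC(=O)[C@@H]2CCCN2C(=O)[C@@H](N)C(C)C)c1=O` gives 10000 nM, the lowest of the three numbers so far. Compound 2 `Cc1cn(C2OC(CO[Si](C)(C)C(C)(C)C)C3(OS(=O)(=O)C=C3N)C2O[Si](C)(C)C(C)(C)C)c(=O)n(CCCNC(=O)[C@@H]2CCCN2C(=O)[C@@H](N)CCCCN)c1=O` gives 47000 nM, and compound 3 `Cc1cn(C2OC(CO[Si](C)(C)C(C)(C)C)C3(OS(=O)(=O)C=C3N)C2O[Si](C)(C)C(C)(C)C)c(=O)n(CCCNC(=O)[C@@H]2CCCN2C(=O)[C@@H](N)CCC(=O)O)c1=O` gives 30000 nM. The measured steps of a 4.7-fold higher number from compound 1 to compound 2 (0.67 log units; beyond the scatter) and a 3.0-fold higher number from compound 1 to compound 3 (0.48 log units; beyond the scatter) are modest and beyond the scatter; both replace isopropyl. The step of a 1.6-fold lower number from compound 2 to compound 3 (0.19 log units; within the scatter) lies within the scatter.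

Compound 4 `Cc1cn(C2OC(CO[Si](C)(C)C(C)(C)C)C3(OS(=O)(=O)C=C3N)C2O[Si](C)(C)C(C)(C)C)c(=O)n(CCCNC(=O)[C@H](C)NC(=O)[C@@H](N)C(C)C)c1=O` differs elsewhere: 1-(((1-amino-2-methylpropyl)carbonyl)amino)ethyl in place of 1-((1-amino-2-methylpropyl)carbonyl)pyrrolidin-2-yl on a carbonyl carbon, with 1-(((1-amino-2-methylpropyl)carbonyl)amino)ethyl in place of 1-((1-amino-2-methylpropyl)carbonyl)pyrrolidin-2-yl on a carbonyl carbon. For the measured compounds named here, no measured step covers this change, so the three steps serve only as a guide to step size. Both steps away from compound 1 raised the number, but two steps at a different place set no direction here. A small upward lean is expected, with no step beyond the scatter, and the expected step in this assay is a 1.5-fold higher number from compound 1 to compound 4 (0.18 log units; within the scatter). For compound 4 the estimated value is 15000 nM, with an expected range of 6000 nM to 40000 nM.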

Compound 4, half-maximal cytotoxic concentration: 11000 nM
Beside the measured number, compound 4's estimate is 1.4-fold (0.13 log units) above it, within the range that was stated.
By their numbers in this assay, from the lowest: compounds 1 and 4 (each within the scatter of the next); then compounds 3 and 2 (each within the scatter of the next).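

In this assay, 1-(((1-amino-2-methylpropyl)carbonyl)amino)ethyl in place of 1-((1-amino-2-methylpropyl)carbonyl)pyrrolidin-2-yl on a carbonyl carbon gives a 1.1-fold higher number from compound 1 to compound 4 (0.04 log units; within the scatter) and leaves compound 1 and compound 4 within the scatter of each other. Among the compounds shown here, this is the first reading at this place, and it shows that the five-membered non-aromatic ring can be exchanged for a group with no ring without a step beyond the scatter. Nothing at hand gives a reason for this result.

Still open, as far as these compounds go, is whether a methyl group on the amide nitrogen of the entering group would read the same. Also open, from the compounds shown here alone, is whether 4-aminobutyl or 2-carboxyethyl in place of isopropyl would raise the number on compound 4 as they do on compound 1.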